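The source may report more compounds than this note shows. Statements on the series, on what has been measured and on what is new or still open speak of the compounds shown alone.

Working notes on the series.

Compound 1 `O=S(=O)(NCCCCNCc1ccc(Br)cc1)c1cc(C(F)(F)F)cc(C(F)(F)F)c1` is the anchor of this set. Among the compounds with values here, in a functional assay on MIA PaCa-2 cells (Homo sapiens) for inhibition, read by MTT assay, with a stated time of 72 h (a lower number here means a stronger inhibitor of growth, a higher number a weaker inhibitor of growth), compound 1 gives 2100 nM, the lowest of the three numbers recorded; compound 2 `O=S(=O)(NCCCCCCNCc1ccc(Br)cc1)c1cc(C(F)(F)F)cc(C(F)(F)F)c1` gives 2970 nM in this assay, and compound 3 `O=S(=O)(NCCCCCCNCc1ccc(Br)cc1)c1cc(Cl)cc(Cl)c1` gives 12000 nM in this assay, the only number set apart from compound 1 beyond the scatter.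

Compound 4 `O=S(=O)(NCCCNCc1ccccc1)c1cc(C(F)(F)F)cc(C(F)(F)F)c1` has not yet been measured in this assay. Relative to compound 1 the change is benzylamino in place of ((4-bromobenzyl)amino)methyl on a saturated chain carbon, three bonds along the chain from a sulfonamide nitrogen. The group that leaves carries one bromine and one more chain carbon than the group that enters.

Within the data shown here, the one measured step that bears on this is the chain change a 1.4-fold higher number from compound 1 to compound 2 (0.15 log units; within the scatter), a step that stayed within the scatter when the chain was made longer. Among the measured compounds shown here, no measured pair in the set speaks to loss of the bromine from the benzyl ring, and the pair compound 2 against compound 3 concerns the sulfonyl aryl substituents, not the benzyl end. Shortening the chain is therefore expected to move this assay little, while removal of the bromine is an open question with no anchor in the data.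

On balance a step of a 1.7-fold higher number from compound 1 to compound 4 (0.22 log units; within the scatter) is expected, in the direction of a somewhat higher number. For compound 4 the estimate in this assay is 3500 nM, with a range from 1200 nM to 10000 nM.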

Compound 4, concentration for 50% growth inhibition: 11000 nM
The estimate for compound 4 lay 3.1-fold (0.50 log units) below the measured number; the measured number lies above the stated range.
By their numbers in this assay, from the lowest: compounds 1 and 2 (each within the scatter of the next); then compounds 4 and 3 (each within the scatter of the next).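

The change of benzylamino in place of ((4-bromobenzyl)amino)methyl on a saturated chain carbon, three bonds along the chain from a sulfonamide nitrogen, gives a 5.2-fold higher number from compound 1 to compound 4 (0.72 log units; beyond the scatter) in this assay, so this end of the molecule is not as forgiving as a 1.4-fold higher number from compound 1 to compound 2 (0.15 log units; within the scatter) alone suggested. The step joins two differences in one, with 8 carbon and 1 bromine in the group that leaves against 7 carbon and no bromine in the group that enters, and the size of the step belongs to the pair of differences taken together, not to either one. No measurement available here accounts for the step.

The compounds shown leave open how much of the step follows the bromine and how much follows the shorter chain, a question that a 4-bromobenzyl group on the chain of compound 4, or an unsubstituted benzyl group on the chain of compound 1, would separate. They also leave open whether a 4-chlorobenzyl group would hold the number of compound 1 2100 nM in this assay.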